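Hydroxamate chain series: aryl change from compound 2

The source may report more compounds than this note shows. Statements on the series, on what has been measured and on what is new or still open speak of the compounds shown alone.

Measured so far:
compound 1 `O=C(CCCCCCn1cc(Nc2ncc(Cl)c(Nc3cccc(Cl)c3)n2)cn1)NO` — 380 nM
compound 2 `O=C(CCCCCn1cc(Nc2ncc(Cl)c(Nc3cccc(Cl)c3)n2)cn1)NO` — 580 nM

In a functional assay on K562 cells (Homo sapiens) for antiproliferative activity, read by MTT assay, with a stated time of 48 h (on this read-out lower numbers stand for stronger inhibition and higher numbers for weaker inhibition), compound 1 gives 380 nM and compound 2 gives 580 nM. Compound 2 carries the highest of the two numbers, but the step of a 1.5-fold higher number from compound 1 to compound 2 (0.18 log units; within the scatter) lies within the scatter, so the two compounds are not ranked against each other on this read-out.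

Compound 3 `O=C(CCCCCn1cc(Nc2ncc(Cl)c(Nc3ccc(F)cc3)n2)cn1)NO` is the next compound for this assay. It differs from compound 2 by 4-fluorophenyl in place of 3-chlorophenyl on a nitrogen on an aromatic ring. Within the data shown here, the one measured step, from compound 1 to compound 2, concerns the chain between the aromatic nitrogen and the hydroxycarbamoyl group and leaves the 3-chlorophenyl untouched; it gives no guide to the present change. The data hold nothing on what the 4-fluorophenyl does in place of the 3-chlorophenyl.

With no bearing step, the expectation for compound 3 is a number near that of compound 2, a step of a 1.2-fold higher number from compound 2 to compound 3 (0.08 log units; within the scatter) that is expected to stay within the scatter, and the range is set wide for that reason. Compound 3 is estimated at 700 nM, between 250 nM and 2000 nM.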

Compound 3, half-maximal inhibitory concentration: 420 nM
For compound 3 the middle estimate is 1.7-fold (0.22 log units) above the measured one, and the stated range covers the measured number.
By their numbers in this assay, from the lowest: compounds 1, 3 and 2 (each within the scatter of the next).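

In this assay, 4-fluorophenyl in place of 3-chlorophenyl on the nitrogen on an aromatic ring gives a 1.4-fold lower number from compound 2 to compound 3 (0.14 log units; within the scatter), so compound 2 and compound 3 are not ranked against each other on this read-out. Among these compounds, this is the first reading at this position, as the earlier step concerned only the chain, and it shows that this one exchange of aryl groups leaves no change that can be read beyond the scatter. The exchange alters both the halogen and its place on the phenyl ring, so this single step cannot assign any share of the outcome to either alteration, and nothing available explains the result.

As far as these compounds go, it remains open whether this position stays as flat with an unsubstituted phenyl or with a phenyl carrying a methoxy group, an amine or a carboxylic acid in place of the halogen. From the compounds shown here alone, it is also open whether 4-fluorophenyl gives the same reading on the longer chain of compound 1, where a comparison with the 3-chlorophenyl pair would show whether the chain and aryl positions act independently.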